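Furan-2-yl in Place of Iodine on a Nucleoside Core

The source may report more compounds than this note shows. Statements on the series, on what has been measured and on what is new or still open speak of the compounds shown alone.

Of the compounds shown here, three that share one core have been tested in a functional assay on HCT-116 cells (Homo sapiens), read by MTT assay, with a stated time of 72 h; a higher number here means a weaker inhibitor, a lower number a stronger inhibitor. Compound 1 `COc1ncnc2c1c(-c1ccoc1)cn2[C@@H]1O[C@H](CO)[C@@H](O)[C@H]1O` carries a furan-3-yl group on the five-membered ring of the core, and in this assay compound 1 gives 130 nM. Compound 2 `C#Cc1cn([C@@H]2O[C@H](CO)[C@@H](O)[C@H]2O)c2ncnc(OC)c12` carries an ethynyl group at the same carbon, and compound 2 gives 5140 nM, a step of a 40-fold higher number from compound 1 to compound 2 (1.60 log units; beyond the scatter). Compound 3 `COc1ncnc2c1c(I)cn2[C@@H]1O[C@H](CO)[C@@H](O)[C@H]1O` carries iodine at that carbon. For compound 3 the assay reports only a limit, > 20000 nM, so compound 3 stands at the weak end of everything measured here. Because of that limit of > 20000 nM in this assay, at which 1 of the 3 values shown sits, the steps of an at least 150-fold higher number from compound 1 to compound 3 (2.18 log units; beyond the scatter) and an at least 3.8-fold higher number from compound 2 to compound 3 (0.59 log units; beyond the scatter) are known only as lower bounds.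

Compound 4 `COc1ncnc2c1c(-c1ccco1)cn2[C@@H]1O[C@H](CO)[C@@H](O)[C@H]1O` differs from compound 3 by furan-2-yl in place of iodo on an aromatic carbon. Within the data shown here, the steps that bear on this change are the two that replaced the furan-3-yl ring of compound 1 with a small group, an at least 150-fold higher number from compound 1 to compound 3 (2.18 log units; beyond the scatter) and a 40-fold higher number from compound 1 to compound 2 (1.60 log units; beyond the scatter); both were large. Since a furan ring now returns, a large step in the opposite direction is expected, an at least 80-fold lower number from compound 3 to compound 4 (1.90 log units; beyond the scatter). Compound 4 is therefore estimated at 250 nM, with a range from 60 nM to 1500 nM.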

Compound 4, half-maximal inhibitory concentration: 40 nM
Estimate against measurement, compound 4: 6.3-fold (0.80 log units) above; measured number outside the range, below it.
By their numbers in this assay, from the lowest: compound 4; then compound 1; then compound 2. At a limit, above all of these: compound 3.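

Moving the point of attachment on the furan ring changes the result at this carbon: in this assay, the swap of furan-3-yl for furan-2-yl gives a 3.3-fold lower number from compound 1 to compound 4 (0.51 log units; beyond the scatter), a modest step. So this position responds not only to whether a furan ring is present but also to how that ring is joined to the shared core, and the furan-2-yl ring goes further than furan-3-yl did in separating itself from the small groups, with a 130-fold lower number from compound 2 to compound 4 (2.11 log units; beyond the scatter) against the ethynyl compound. Compound 3 has only a limit, which means that the step to the furan-2-yl compound, an at least 500-fold lower number from compound 3 to compound 4 (2.69 log units; beyond the scatter), is a lower bound and its true size is unknown: the limit of > 20000 nM in this assay, at which 1 of the 4 values shown sits.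

Among these compounds, with only two furan rings and two small groups at this carbon, it remains open whether the low numbers belong to furan rings in particular or to aromatic rings more widely, which a thiophene or a phenyl ring would help to settle. From the compounds shown here alone, it is also open how an amine or a longer chain at the same carbon would read in this assay.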